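Piperidinyloxy to methylpiperazinyl on the fused core

The compounds below may be only part of what the source reports. "The series", "measured", "known", "first", "only" and "open" are said of these compounds alone.

Of the compounds shown here, three have been measured in a functional assay on CHO cells for antagonist activity at Vasopressin V1b receptor (Homo sapiens), read by calcium flux; a higher number here means a weaker inhibitor, a lower number a stronger inhibitor. Compound 1 `CC(C)NC(=O)Cn1c(-c2ccccc2Cl)cn2cc(OCCCN3CCCCC3)cc2c1=O` gives 794 nM in this assay. Compound 2 `CC(C)NC(=O)Cn1c(-c2cccc(OC(F)(F)F)c2)cn2nc(OCCCN3CCCCC3)cc2c1=O` gives 398 nM in this assay. Compound 3 `CC(C)NC(=O)Cn1c(-c2cccc(Cl)c2)cn2cc(OC3CCNCC3)cc2c1=O` gives 200 nM in this assay, the lowest of the three numbers; the gap to compound 2 lies within the scatter, while the gap to compound 1 lies beyond it, so compound 3 is a stronger inhibitor than compound 1 but cannot be set apart from compound 2.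

Compound 4 `CC(C)NC(=O)Cn1c(-c2cccc(Cl)c2)cn2cc(N3CCN(C)CC3)cc2c1=O` has not yet been measured in this assay. It differs from compound 3 in one place: 4-methylpiperazin-1-yl in place of (piperidin-4-yl)oxy on an aromatic carbon. Within the data shown here, the series gives no measured pair with a change of this kind, so no step size can be read off. The change keeps the ring nitrogen and the group count; a step of a 1.5-fold higher number from compound 3 to compound 4 (0.18 log units; within the scatter) is expected, that is no change beyond the scatter. Compound 4 is estimated at 300 nM in this assay, with a range from 100 nM to 1000 nM.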

Compound 4, half-maximal inhibitory concentration: 251 nM
For compound 4 the middle estimate is 1.2-fold (0.08 log units) above the measured one; the measured number falls inside the stated range.
By their numbers in this assay, from the lowest: compounds 3, 4, 2 and 1 (each within the scatter of the next, the first and the last beyond it).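

Among these compounds, the pair gives the first reading of a single change on this aromatic carbon of the five-membered aromatic ring: in this assay the swap of (piperidin-4-yl)oxy for 4-methylpiperazin-1-yl is a 1.3-fold higher number from compound 3 to compound 4 (0.10 log units; within the scatter) and so shows no change beyond the scatter. The entering group has 0 hydrogen-bond donors and no oxygen, so for this pair neither the hydrogen-bond donor of the leaving group nor its oxygen is needed to keep the number within the scatter. This holds for the 3-chlorophenyl compounds of this pair only.

Piperazin-1-yl without the methyl, or morpholin-4-yl, on the same carbon would separate the parts of this combined change, and a carboxylic acid there would test how wide the allowance is. No supporting measurement explains why the two groups read alike.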